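The compounds below may be only part of what the source reports. "The series", "measured", "known", "first", "only" and "open" are said of these compounds alone.

Measured so far:
compound 1 `COc1cc(/C=C/C(=O)Nc2ccccc2)ccc1OCCCCN(C)C` — 1.57
compound 2 `COc1cc(/C=C/C(=O)Nc2ccccc2)ccc1OCCCCCN1CCCC1` — 1.64
compound 3 `COc1cc(/C=C/C(=O)Nc2ccccc2)ccc1OCCCCCCCCN(C)C` — 1.74

In a physicochemical assay for lipophilicity, using the shake flask method, measured as octanol-water partition, at pH 7.4 (on this read-out lower numbers stand for lower lipophilicity and higher numbers for higher lipophilicity), compound 3 gives 1.74, the highest of the three numbers, but its gaps to the others are small: a number 0.10 log units higher from compound 2 to compound 3 (within the scatter) and a number 0.17 log units higher from compound 1 to compound 3 (within the scatter) are both within the scatter, so the three compounds cannot be set in order. Compound 4 `COc1cc(/C=C/C(=O)Nc2ccccc2)ccc1OCCCCCCCCCCN1CCCCC1` has not yet been measured. Its difference from compound 3 is 2-(piperidin-1-yl)ethyl in place of dimethylamino on a saturated chain carbon, eight bonds along the chain from an oxygen on an aromatic ring. Among the compounds with values here, two measured steps bear on this change: a number 0.07 log units higher from compound 1 to compound 2 (within the scatter) swapped an open amine for a ring amine, and a number 0.17 log units higher from compound 1 to compound 3 (within the scatter) lengthened the chain by four carbons; both stayed within the scatter, as did a number 0.10 log units higher from compound 2 to compound 3 (within the scatter). Compound 4 combines a longer chain with a ring amine, so a step somewhat larger than those, upward, is expected, though it may still fall within the scatter. The expected step is a number 0.21 log units higher from compound 3 to compound 4 (within the scatter). Compound 4 is therefore estimated at 1.95 in this assay, with a range from 1.6 to 2.4.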

Compound 4, partition coefficient: 1.83
The estimate for compound 4 lay 0.12 log units above the measured number; the range from low to high includes it.
By their numbers in this assay, from the lowest: compounds 1, 2, 3 and 4 (each within the scatter of the next).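

In this assay, 2-(piperidin-1-yl)ethyl in place of dimethylamino, on a saturated chain carbon eight bonds along the chain from an oxygen on an aromatic ring, gives a number 0.09 log units higher from compound 3 to compound 4 (within the scatter). The larger structural changes also stay inside the scatter, with a number 0.19 log units higher from compound 2 to compound 4 (within the scatter) and a number 0.26 log units higher from compound 1 to compound 4 (within the scatter), so even 6-(piperidin-1-yl)hexyl in place of dimethylamino does not separate the two compounds it links on this read-out. No supporting measurement is available to explain this result.

The compounds shown place no two different amines on a chain of the same length, so the contributions of the amine and the chain cannot be read apart. As far as these compounds go, it remains open whether a morpholine, a carboxylic acid or a still longer chain at this position would give a step beyond the scatter.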